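Moving the fluorine on the benzyl group of the triazole

This account rests on a few compounds, and the source may have more. Where it says the series, first, only, none or still open, it means among the compounds named here.

Measured so far:
compound 1 `COc1ccc(C(=O)/C=C/c2ccc(OCc3cn(Cc4ccccc4Br)nn3)cc2)cc1`, 50%
compound 2 `COc1ccc(C(=O)/C=C/c2ccc(OCc3cn(Cc4cccc(F)c4)nn3)cc2)cc1`, 48%

In a functional assay on MIA PaCa-2 cells (Homo sapiens) for inhibition, read by MTT assay, with a stated time of 48 h, tested at 10 uM (a higher number here means more inhibition of growth at the concentration tested, a lower number less inhibition of growth), compound 2 gives the lower of the two numbers, with compound 1 nearest and within the scatter of it. Compound 3 `COc1ccc(C(=O)/C=C/c2ccc(OCc3cn(Cc4ccc(F)cc4)nn3)cc2)cc1` differs from compound 2 only in 4-fluorophenyl in place of 3-fluorophenyl on a saturated chain carbon bound to an aromatic nitrogen. For the measured compounds named here, the one step that bears on this place, a number 2 percentage points lower from compound 1 to compound 2 (within the scatter), lay within the scatter despite a larger change of group there, so no shift beyond the scatter is expected for no change at the digits printed from compound 2 to compound 3 (within the scatter) in this assay. Compound 3 is therefore estimated at 48%, with a range from 36% to 60%.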

Compound 3, percent growth inhibition at one concentration: 6%
Beside the measured number, compound 3's estimate is 42 percentage points above it, and the stated range ends above it.
By their numbers in this assay, from the lowest: compound 3; then compounds 2 and 1 (each within the scatter of the next).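

In this assay there is a number 42 percentage points lower from compound 2 to compound 3 (beyond the scatter) when 4-fluorophenyl replaces 3-fluorophenyl on a saturated chain carbon bound to an aromatic nitrogen, although the two groups hold the same atoms. There is also a number 44 percentage points lower from compound 1 to compound 3 (beyond the scatter) with 4-fluorophenyl in place of 2-bromophenyl, whereas 3-fluorophenyl in place of 2-bromophenyl stayed within the scatter. Moving the fluorine alone is thus enough to separate these compounds at this place. Nothing available here accounts for this difference. As far as these compounds go, whether plain phenyl or a methoxy-bearing phenyl would side with compound 2 or compound 3 stays open.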